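The compounds below may be only part of what the source reports. "The series", "measured", "known", "first", "only" and "open" are said of these compounds alone.

Values so far in an ADME assay on the whole organism for inhibition, with Echinochloa crus-galli var. formosensis as the target, with a stated time of 4 days; a lower number here means a stronger inhibitor, a higher number a weaker inhibitor

- compound 1 `CCCCNc1nc(Cl)nc(N[C@H](C)c2ccccc2)n1` gives 38900 nM
- compound 2 `CCCN(CC)c1nc(Cl)nc(N[C@@H](C)c2ccccc2)n1` gives 282 nM
- compound 3 `CC[C@@H](C)Nc1nc(Cl)nc(N[C@@H](C)c2ccccc2)n1` gives 7410 nM

Of these three numbers, compound 3 (7410 nM) is the second highest, lower than compound 1 and higher than compound 2. Compound 4 `CCCCNc1nc(Cl)nc(N[C@@H](C)c2ccccc2)n1` has butyl in place of sec-butyl on a nitrogen on an aromatic ring. For the measured compounds named here, the only measured step at this place (a 26-fold higher number from compound 2 to compound 3 (1.42 log units; beyond the scatter)) was large, so the number can respond strongly to the group there. Going by the values given here, that step swapped a different group, however, and no measured pair tests this exact swap. A modest fall in the number is therefore expected, smaller than that step. The expected change is (a 2.5-fold lower number from compound 3 to compound 4 (0.39 log units; beyond the scatter)) in this assay terms. For compound 4 the estimate is 3000 nM with an expected range from 500 nM to 15000 nM as its likely span.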

Compound 4, half-maximal inhibitory concentration: 12900 nM
Estimate against measurement, compound 4: 4.3-fold (0.63 log units) below, and the stated range covers the measured number.
By their numbers in this assay, from the lowest: compound 2; then compounds 3 and 4 (each within the scatter of the next); then compound 1.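

In this assay, the straight butyl and branched sec-butyl chains on this nitrogen cannot be told apart, with a 1.7-fold higher number from compound 3 to compound 4 (0.24 log units; within the scatter), so branching here shows no measurable effect. Butylamino, however, stands well apart from ethyl(propyl)amino, with a 46-fold higher number from compound 2 to compound 4 (1.66 log units; beyond the scatter). The drawn configuration also matters, with a 3.0-fold lower number from compound 1 to compound 4 (0.48 log units; beyond the scatter), and nothing else separates that pair: the fact that compounds 1 and 4 differ only in the configuration as drawn

Going by these compounds, whether dimethylamino, or a longer chain such as hexylamino, would give a number nearer that of compound 2 or that of compound 4 remains open.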